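This account rests on a few compounds, and the source may have more. Where it says the series, first, only, none or still open, it means among the compounds named here.

Measured so far:
Compound 1, `COc1ccc(N2CCN(C(=O)c3nc4cc(C(F)(F)F)ccc4s3)CC2)cc1`, in an ADME assay on RAW264.7 cells (Mus musculus) for cytotoxicity, read by MTT assay, with a stated time of 72 h, tested at 50 ug/mL; a lower number here means less inhibition, a higher number more inhibition at the concentration tested (going by the name of the read-out): 19.4%
Compound 2, `COc1ccc(N2CCN(C(=O)c3nc4cc(Cl)ccc4s3)CC2)cc1`, in this assay: 42.8%
Compound 3, `O=C(c1nc2ccccc2s1)N1CCN(c2ccncc2)CC1`, in this assay: 62%

Compound 2 stands second highest of the three numbers in this assay. Its nearest neighbour is compound 3, which gives 62%, a number beyond the scatter above it; its furthest is compound 1, which gives 19.4%, a number beyond the scatter below it.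

Compound 4, `O=C(c1nc2cc(Cl)ccc2s1)N1CCN(c2cnccn2)CC1`, differs from compound 2 in one place: pyrazin-2-yl in place of 4-methoxyphenyl on an amine nitrogen in a ring.

For the measured compounds named here, the only measured step, a number 23.4 percentage points higher from compound 1 to compound 2 (beyond the scatter), concerns a group on an aromatic carbon of the core and not the group on the amine nitrogen, so it does not bear on this change. Going by the values given here, compound 3 carries a different group on that nitrogen, but it differs from compound 2 in two places, and its two values show only that compound 3 sits higher than compound 2; that cannot be tied to one change. Among the compounds with values here, with no measured step bearing on the change, the expectation for compound 4 is a step no larger than the scatter: a number 5.2 percentage points higher from compound 2 to compound 4 (within the scatter). Compound 4 is therefore estimated at 48%, with a range from 30% to 66%.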

Compound 4, a percentage reported as inhibition, at one concentration (the size of the read-out at that concentration, not a potency): 54.9%
Compound 4: the middle estimate sits 6.9 percentage points below what was measured, within the range that was stated.
By their numbers in this assay, from the lowest: compound 1; then compound 2; then compounds 4 and 3 (each within the scatter of the next).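

In this assay the group on the amine nitrogen proves able to shift the number on its own: with the rest of the molecule unchanged, pyrazin-2-yl in place of 4-methoxyphenyl gives a number 12.1 percentage points higher from compound 2 to compound 4 (beyond the scatter) as its step. For the compounds shown here, until now the only single-place step concerned a group on an aromatic carbon of the core, so this is the first direct reading at this position. Nothing measured here accounts for the step.

The change removes a carbon-only ring with its methoxy and brings in a ring with two hetero atoms in one move, so the compounds shown do not separate these parts, and a plain phenyl or a pyridin-2-yl on that nitrogen would bear on the question. From the compounds shown here alone, whether the step would hold with trifluoromethyl on the core also stays open.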